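Removing the Hydroxy Group of Compound 3

The source may report more compounds than this note shows. Statements on the series, on what has been measured and on what is new or still open speak of the compounds shown alone.

Measured compounds:
Compound 1 `O=C(Nc1cc(C(F)(F)F)cc(C(F)(F)F)c1)c1cc(Br)ccc1O`: 300 nM
Compound 2 `N#Cc1ccc(NC(=O)c2cc(-c3cccnc3)ccc2O)cc1`: 8330 nM
Compound 3 `N#Cc1ccc(NC(=O)c2ccc3ccccc3c2O)cc1`: 2720 nM

All three carry a hydroxy on the aromatic carbon ortho to the carbonyl-bearing position of an anilide, and were read in a functional assay on KG-1 cells (Homo sapiens) for cytotoxicity, read by luminescence and CellTiter-Glo, with a stated time of 3 days; on this read-out higher numbers stand for weaker inhibition and lower numbers for stronger inhibition. In this assay compound 1 gives 300 nM, compound 2 gives 8330 nM and compound 3 gives 2720 nM. Compound 3 thus stands second highest of the three numbers; its nearest neighbour is compound 2, at a higher number, and the gap between them lies beyond the scatter. The gap between compound 3 and compound 1 is larger still and also beyond the scatter. Among the compounds with values here, no single-point step between measured compounds is available, so these gaps are only read as the values show them.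

Compound 4 `N#Cc1ccc(NC(=O)c2ccc3ccccc3c2)cc1` is not yet measured. It differs from compound 3 in one place: hydrogen in place of hydroxy on an aromatic carbon. Within the data shown here, since the hydroxy is present in every measured compound, the series itself gives no step of this kind to lean on. The expectation for compound 4 is a move to a higher number, beyond the scatter, with a 3.3-fold higher number from compound 3 to compound 4 (0.52 log units; beyond the scatter) as the estimated step. Compound 4 is thus expected at 9000 nM, with a range from 3000 nM to 30000 nM.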

Compound 4, half-maximal inhibitory concentration: > 10000 nM
Compound 4 ended at the assay's limit; the forecaster's own chance of this, stated with the estimate: 30%; middle value at least 1.1-fold (0.04 log units) away from the limit.
By their numbers in this assay, from the lowest: compound 1; then compound 3; then compound 2. At a limit, above all of these: compound 4.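

In this assay compound 4 gives > 10000 nM, which is a limit of the assay and not a number. Within the data shown here, this is the first step that changes one place only, and it shows that the hydroxy on this aromatic carbon, ortho to a large group, counts for the read-out: hydrogen in its place gives an at least 3.6-fold higher number from compound 3 to compound 4 (0.56 log units; beyond the scatter). The step can be read only as a lower bound, and its full size stays hidden at the limit: the limit of > 10000 nM in this assay, at which 1 of the 4 values shown sits.

From the compounds shown here alone, whether an amine, a methoxy group or a carboxylic acid on this carbon would hold the number of compound 3 remains open. Also open, going by these compounds, is whether the same change on the core of compound 1 or compound 2 would give a step of like size.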